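From 4-chlorophenyl to 2-chlorophenyl on a shared core

A few compounds are considered here, and "the series" means these few. Any claim that something is new, unique, unknown or untested is made for them only; others in the source may bear on it.

Of the compounds shown here, three sharing one core have been measured in a functional assay on MDA-MB-231 cells (Homo sapiens) for cytotoxicity, read by sulforhodamine B assay, with a stated time of 72 h; a higher number here means a weaker inhibitor of growth, a lower number a stronger inhibitor of growth. Compound 1 (`CCCCCCCCC(=O)N1c2ccccc2CCC1C(=O)Nc1ccccc1C(F)(F)F`), with octyl on the carbonyl carbon, gives 3350 nM. Compound 2 (`O=C(Nc1ccccc1C(F)(F)F)C1CCc2ccccc2N1C(=O)c1cccc(Cl)c1`), with 3-chlorophenyl there, gives 288 nM. Compound 3 (`O=C(Nc1ccccc1C(F)(F)F)C1CCc2ccccc2N1C(=O)c1ccc(Cl)cc1`), with 4-chlorophenyl there, gives 533 nM. Compound 3 thus stands with compound 2 at the low end of these numbers, well clear of compound 1.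

Replacing octyl with a chlorophenyl group produced clear steps: a 12-fold lower number from compound 1 to compound 2 (1.07 log units; beyond the scatter) and a 6.3-fold lower number from compound 1 to compound 3 (0.80 log units; beyond the scatter). Moving the chlorine between the two tested chlorophenyl groups gave only a 1.9-fold higher number from compound 2 to compound 3 (0.27 log units; within the scatter), which is within the scatter.

Compound 4 (`O=C(Nc1ccccc1C(F)(F)F)C1CCc2ccccc2N1C(=O)c1ccccc1Cl`) has not yet been measured. It has 2-chlorophenyl in place of 4-chlorophenyl on a carbonyl carbon. Within the data shown here, the step between compound 2 and compound 3 is the closest guide, although no measured compound carries 2-chlorophenyl, so the range is kept wide. No step beyond the scatter is expected in this assay, and the estimated step is a 1.2-fold lower number from compound 3 to compound 4 (0.07 log units; within the scatter). For compound 4 the expected value is 450 nM, with an estimated range from 180 nM to 1100 nM.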

Compound 4, concentration for 50% growth inhibition: 2530 nM
Beside the measured number, compound 4's estimate is 5.6-fold (0.75 log units) below it; the whole stated range lies below it.
By their numbers in this assay, from the lowest: compounds 2 and 3 (each within the scatter of the next); then compounds 4 and 1 (each within the scatter of the next).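

Among these compounds, on this carbonyl carbon, the earlier compounds had left the place of the chlorine on the chlorophenyl group looking of little consequence, but in this assay the 2-chlorophenyl group gives a 4.7-fold higher number from compound 3 to compound 4 (0.68 log units; beyond the scatter) and an 8.8-fold higher number from compound 2 to compound 4 (0.94 log units; beyond the scatter) even though the atoms are the same and only joined differently. A chlorophenyl group as such therefore does not carry the lower numbers that compound 2 and compound 3 showed against the octyl group, and a 1.3-fold lower number from compound 1 to compound 4 (0.12 log units; within the scatter) is all that separates the 2-chlorophenyl group from that chain. The data offer no measured explanation for why the 2-chlorophenyl group parts from the other two chlorophenyl groups.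

The compounds shown leave open whether the higher number belongs to chlorine itself or to any group at that place on the ring, which a 2-fluorophenyl or 2-methylphenyl group would begin to separate. They also leave open where an unsubstituted phenyl group would fall among these compounds, and so whether the 3-chlorophenyl and 4-chlorophenyl groups owe their lower numbers to the chlorine at all.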